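Swapping Methoxy Groups for Halogens on the Anilino Ring

The source may hold more compounds than are shown below. What is called first, only, known or untested is meant among the compounds shown, and "the series" means these compounds.

Compound 2 `COc1ccc(Nc2c(-c3ccc4[nH]nc(C)c4c3)nc3cnc(N4CCN(C)CC4)cn23)cc1OC` gives 6.27% in a functional assay on MV4-11 cells (Homo sapiens) for inhibition, with a stated time of 120 h, tested at 10 uM (on this read-out lower numbers stand for less inhibition and higher numbers for more inhibition at the one concentration tested (going by the name of the read-out)), the lowest of the two numbers measured; compound 1 `Cc1n[nH]c2ccc(-c3nc4cnc(N5CCN(C)CC5)cn4c3Nc3ccc(Br)cc3Cl)cc12` gives 70.5%. Among the measured compounds shown here, one measured step bears directly on the change ahead: a number 64.2 percentage points lower from compound 1 to compound 2 (beyond the scatter). Compound 3 `Cc1n[nH]c2ccc(-c3nc4cnc(N5CCN(C)CC5)cn4c3Nc3ccc(F)c(Cl)c3)cc12` differs from compound 2 by 3-chloro-4-fluorophenyl in place of 3,4-dimethoxyphenyl on a nitrogen on an aromatic ring, which brings halogens back onto the phenyl ring, as in compound 1, though not the same ones. Because the step of a number 64.2 percentage points lower from compound 1 to compound 2 (beyond the scatter) was large, a rise well beyond the scatter is expected in this assay. Compound 3 is estimated at 50%, ranging from 20% to 80%, which means a number 43.7 percentage points higher from compound 2 to compound 3 (beyond the scatter).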

Compound 3, a percentage reported as inhibition, at one concentration (the size of the read-out at that concentration, not a potency): 84.1%
For compound 3 the middle estimate is 34.1 percentage points below the measured one; measured number above the stated range.
By their numbers in this assay, from the lowest: compound 2; then compound 1; then compound 3.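

Putting 3-chloro-4-fluorophenyl in place of 3,4-dimethoxyphenyl gives a number 77.8 percentage points higher from compound 2 to compound 3 (beyond the scatter) in this assay and shows that high inhibition at this position does not depend on the exact halogens of compound 1. Which halogens and where they sit still matters, as 3-chloro-4-fluorophenyl in place of 4-bromo-2-chlorophenyl gives a number 13.6 percentage points higher from compound 1 to compound 3 (beyond the scatter) in the same read-out. No measurement shown explains either step.

Compound 1 and compound 3 differ in both halogens and their placement, so neither change can be credited alone. On these data alone, how a phenyl ring carrying a single fluorine, a trifluoromethyl group or an amine would behave here remains open.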